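A few compounds are considered here, and "the series" means these few. Any claim that something is new, unique, unknown or untested is made for them only; others in the source may bear on it.

Compound 1 `Oc1ccc(CNc2cc(C(F)(F)F)cc3[nH]ncc23)cc1` is tested in an assay for inhibition of Tryptophan 2,3-dioxygenase (Homo sapiens), with stated times of 10 min and 60 min (a higher number here means a weaker inhibitor, a lower number a stronger inhibitor), where compound 1 gives 2550 nM. Of the two numbers shown this is the lowest; the nearest neighbour is compound 2 `Oc1ccc(CNc2cc(C(F)(F)F)cc3[nH]ncc23)c(Cl)c1`, which in this assay gives 2680 nM, a step of a 1.1-fold higher number from compound 1 to compound 2 (0.02 log units; within the scatter). Compound 3 `COC(=O)c1cc(NCc2ccccc2[N+](=O)[O-])c2cn[nH]c2c1` yields only a limit in this assay, namely > 100000 nM, which is the limit of > 100000 nM in this assay, at which 1 of the 3 values shown sits. Compound 4 `Nc1cccc(CNc2cc(C(F)(F)F)cc3[nH]ncc23)c1` is not yet measured; it differs from compound 1 by 3-aminophenyl in place of 4-hydroxyphenyl on a saturated chain carbon bound to a nitrogen on an aromatic ring. Among the measured compounds shown here, no measured step touches that part of the molecule, and the single measured step, a 1.1-fold higher number from compound 1 to compound 2 (0.02 log units; within the scatter), stayed within the scatter, so only a modest change is expected. For compound 4 the expected number in this assay is 4000 nM, within 1300 nM to 12000 nM. That estimate means an expected step of a 1.6-fold higher number from compound 1 to compound 4 (0.20 log units; within the scatter).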

Compound 4, half-maximal inhibitory concentration: 2510 nM
Compound 4: middle estimate off by 1.6-fold (0.20 log units), on the high side; low and high end bracket the measured number.
By their numbers in this assay, from the lowest: compounds 4, 1 and 2 (each within the scatter of the next). At a limit, above all of these: compound 3.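

Replacing 4-hydroxyphenyl with 3-aminophenyl on a saturated chain carbon bound to a nitrogen on an aromatic ring gives, in this assay, a 1.0-fold lower number from compound 1 to compound 4 (0.01 log units; within the scatter). So this position accepts a change of the whole ring group, not just the added chloro of the earlier step, with no measurable effect on the number. Nothing measured here accounts for this result.

The swap alters both the group on the ring and its place, so the two effects remain unseparated. 3-Hydroxyphenyl, 4-aminophenyl, plain phenyl or a ring bearing a carboxylic acid could help to tell them apart.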